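Bromo for chloro on the salicylanilide core

This account rests on a few compounds, and the source may have more. Where it says the series, first, only, none or still open, it means among the compounds named here.

The series is built on the core shown by compound 1 `O=C(Nc1cc(C(F)(F)F)cc(C(F)(F)F)c1)c1ccc(Cl)cc1O`, an anilide carrying a hydroxy group beside the carbonyl and two trifluoromethyl groups on the aniline ring. In a functional assay on KG-1 cells (Homo sapiens) for cytotoxicity, read by luminescence and CellTiter-Glo, with a stated time of 3 days (on this read-out higher numbers stand for weaker inhibition and lower numbers for stronger inhibition), compound 1 gives 620 nM. Compound 2 `O=C(Nc1cc(Cl)cc(Cl)c1)c1cc(F)ccc1O`, with two chloro groups on the aniline and a fluoro on the acid ring, gives 780 nM in this assay, and compound 3 `O=C(Nc1cc(C(F)(F)F)cc(C(F)(F)F)c1)c1cc(Cl)c(F)cc1O`, which keeps the two trifluoromethyl groups and carries chloro and fluoro on the acid ring, gives 470 nM. Compound 1 sits between these two numbers, and all three values lie within the usual scatter of one another, so no one of them can be set apart from the others.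

Compound 4 `O=C(Nc1cc(C(F)(F)F)cc(C(F)(F)F)c1)c1ccc(Br)cc1O` has not been measured. It differs from compound 1 in a single place: bromo in place of chloro on an aromatic carbon. The bromo takes the place on the aromatic carbon meta to a hydroxy group and para to a large group; nothing else changes.

Among the compounds with values here, no measured pair in the set isolates a halogen exchange of this kind, so the step is expected to be small, with no clear direction and none beyond the scatter. Compound 4 is therefore estimated at 520 nM in this assay, within a range of 260 nM to 1050 nM, which corresponds to an expected step of a 1.2-fold lower number from compound 1 to compound 4 (0.08 log units; within the scatter).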

Compound 4, half-maximal inhibitory concentration: 830 nM
Compound 4: the middle estimate sits 1.6-fold (0.20 log units) below what was measured; measured number inside the range.
By their numbers in this assay, from the lowest: compounds 3, 1, 2 and 4 (each within the scatter of the next).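

Within the data shown here, this pair is the first in the set to differ in one place only, and so gives a direct reading of a halogen exchange: in this assay, bromo in place of chloro on the aromatic carbon meta to a hydroxy group and para to a large group gives a 1.3-fold higher number from compound 1 to compound 4 (0.13 log units; within the scatter), with the rest of the core of compound 1 unchanged. On this read-out, chloro and bromo cannot be told apart at this position, and going from 4-chloro-2-hydroxyphenyl to 4-bromo-2-hydroxyphenyl is tolerated. Nothing measured on the two halogens bears on this result, so the pair gives the size of the step but no explanation for it.

The compounds shown leave open whether a group of another kind at this position, such as an amine, a methoxy group or a carboxylic acid, would move the number beyond the scatter. They also leave open whether the same exchange would give a step of like size with two chloro groups on the aniline ring in place of the two trifluoromethyl groups.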